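The source may report more compounds than this note shows. Statements on the series, on what has been measured and on what is new or still open speak of the compounds shown alone.

Measured compounds:
Compound 1 `COc1cc2ncnc(Nc3ccc(F)c(Cl)c3)c2cc1OCCCCC(=O)Nc1ccc(S(N)(=O)=O)cc1` gives 35600 nM in a functional assay on NCI-H1975 cells (Homo sapiens) for antiproliferative activity, read by MTT assay, with a stated time of 72 h; a higher number here means a weaker inhibitor, a lower number a stronger inhibitor.
Compound 2 `C#Cc1cccc(Nc2ncnc3cc(OC)c(OCCCCC(=O)Nc4ccc(S(N)(=O)=O)cc4)cc23)c1` gives 18800 nM in this assay.
Compound 3 `COc1cc2ncnc(Nc3ccc(F)cc3)c2cc1OCCCCC(=O)Nc1ccc(S(N)(=O)=O)cc1` gives > 40000 nM in this assay, which is a limit of the assay and not a number.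

Of the two numbers shown, compound 1 carries the larger one, yet a 1.9-fold lower number from compound 1 to compound 2 (0.28 log units; within the scatter) stays within the scatter, so the two cannot be told apart. Compound 3 sits at the limit (the limit of > 40000 nM in this assay, at which 1 of the 3 values shown sits), so nothing more than a floor is known for it.

The unmeasured compound 4 `COc1cc2ncnc(Nc3ccc(Br)cc3)c2cc1OCCCCC(=O)Nc1ccc(S(N)(=O)=O)cc1` differs from compound 1 in one place: 4-bromophenyl in place of 3-chloro-4-fluorophenyl on a nitrogen on an aromatic ring. Within the data shown here, two measured steps bear on this. Removing the chloro group from compound 1 gave an at least 1.1-fold higher number from compound 1 to compound 3 (0.05 log units; that floor lies within the scatter), ending at the limit. Going from compound 2 to a plain 4-fluorophenyl gave an at least 2.1-fold higher number from compound 2 to compound 3 (0.32 log units; beyond the scatter). Both point to a 4-substituted phenyl without the chloro group giving a larger number, though only weakly. Compound 4 is therefore expected to sit near compound 1 or somewhat higher, with a 1.1-fold higher number from compound 1 to compound 4 (0.03 log units; within the scatter) the estimated step, and a real chance that only a limit is reported. The estimate for compound 4 is 38000 nM, ranging from 15000 nM to 90000 nM.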

Compound 4, half-maximal inhibitory concentration: 23300 nM
The estimate for compound 4 lay 1.6-fold (0.21 log units) above the measured number; the range from low to high includes it.
By their numbers in this assay, from the lowest: compounds 2, 4 and 1 (each within the scatter of the next). At a limit, above all of these: compound 3.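

In this assay, a 1.5-fold lower number from compound 1 to compound 4 (0.18 log units; within the scatter) and a 1.2-fold higher number from compound 2 to compound 4 (0.09 log units; within the scatter), so at this place on the nitrogen, 4-bromophenyl cannot be told apart from either 3-chloro-4-fluorophenyl or 3-ethynylphenyl. Compound 4 therefore shows what compound 3 could not: a phenyl ring with a single group and no chloro can still give a measured number here, so the chloro group of compound 1 is not required for that. Bromo in place of fluoro gives an at least 1.7-fold lower number from compound 3 to compound 4 (0.23 log units; that floor lies within the scatter), and this step can only be read as a floor because compound 3 sits at a limit of the assay: the limit of > 40000 nM in this assay, at which 1 of the 4 values shown sits.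

With compounds 1, 2 and 4 each within the scatter of the next, this position has so far shown no clear gain from any group on the ring, and the one real separation is the modest step to compound 3. Still open, going by these compounds, is whether a different group at this place, such as a 4-methoxyphenyl or a 4-aminophenyl, would move the number clearly, and whether a longer chain or a carboxylic acid at the far end of the molecule would matter more than the ring does.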